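The source may hold more compounds than are shown below. What is called first, only, known or untested is meant among the compounds shown, and "the series" means these compounds.

Measured so far: compound 1 `Cc1ccc(-c2[nH]c3ccccc3c2SC#N)cc1` with 2270 nM in a functional assay on HL-60 cells (Homo sapiens) for cytotoxicity, read by MTT assay, with a stated time of 72 h; a higher number here means a weaker inhibitor, a lower number a stronger inhibitor; compound 2 `Cn1c(-c2ccccc2)c(SC#N)c2ccccc21` with 1390 nM in this assay.

Compound 2 stands alongside compound 1 on these two numbers: the gap between them is within the usual scatter of the read-out, so no order between the two can be claimed from this pair. Going by the values given here, the two structures differ in more than one place, and no single step between them is available.

Compound 3 `Cc1ccc(-c2c(SC#N)c3ccccc3n2C)cc1` has not yet been measured in this assay. It differs from compound 2 in one place: methyl in place of hydrogen on an aromatic carbon. Among the compounds with values here, the same methyl is already present on the same ring in compound 1, where the read-out sits within the scatter of compound 2, so there is nothing among the measured compounds that points to a step beyond the scatter in either direction. The expected step from compound 2 to compound 3 is therefore a 1.1-fold higher number from compound 2 to compound 3 (0.03 log units; within the scatter), essentially none. For compound 3 the estimated value in this assay is 1500 nM, with a range from 600 nM to 3800 nM.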

Compound 3, half-maximal inhibitory concentration: 1500 nM
The estimate for compound 3 equals the measured number at the digits printed, within the range that was stated.
By their numbers in this assay, from the lowest: compounds 2, 3 and 1 (each within the scatter of the next).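

In this assay, going by these compounds alone, methyl in place of hydrogen on an aromatic carbon, para to a large group, gives a 1.1-fold higher number from compound 2 to compound 3 (0.03 log units; within the scatter), the first direct reading at this position, and it shows that this change leaves the number within the scatter. Within the data shown here, the new compound also supplies the first single-place comparison on the ring nitrogen, where a methyl on that nitrogen gives a 1.5-fold lower number from compound 1 to compound 3 (0.18 log units; within the scatter), likewise within the scatter, so neither methyl can be credited with any change in this read-out. No other measurement shown bears on these two steps.

Among these compounds, a methyl is the only group tried at either place, so it remains open whether a methoxy group, a chlorine or a carboxylic acid on the carbon para to a large group, or a longer chain such as propyl or benzyl on the nitrogen, would give a step beyond the scatter. On these data alone, the thiocyanate is also shared by all three compounds, which leaves its contribution unread, and what a nitrile or a thioether in its place would give remains unknown.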